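The source may report more compounds than this note shows. Statements on the series, on what has been measured and on what is new or still open speak of the compounds shown alone.

Compound 3 `O=C(Nc1ccc(-n2cc(-c3ccncc3)c(-c3ccc(Cl)c(O)c3)n2)cc1)c1cc(Cl)cc(Cl)c1` gives 2750 nM in a functional assay on SK-MEL-28 cells (Homo sapiens) for antiproliferative activity, read by sulforhodamine B assay, with a stated time of 48 h; a lower number here means a stronger inhibitor, a higher number a weaker inhibitor. This is the lowest of the three numbers, but compound 1 `COc1cc(-c2nn(-c3ccc(NC(=O)c4ccc(Cl)c(C(F)(F)F)c4)cc3)cc2-c2ccncc2)ccc1Cl` with 2800 nM and compound 2 `O=C(Nc1ccc(-n2cc(-c3ccncc3)c(-c3ccc(Cl)c(O)c3)n2)cc1)c1ccc(Cl)c(Cl)c1` with 2940 nM both lie within the scatter of it, so no order among the three can be read. Among the compounds with values here, the one change on the aryl ring of the amide, a 1.1-fold lower number from compound 2 to compound 3 (0.03 log units; within the scatter), moved nothing beyond the scatter. Compound 4 `O=C(Nc1ccc(-n2cc(-c3ccncc3)c(-c3ccc(Cl)c(O)c3)n2)cc1)c1ccc(Cl)c(C(F)(F)F)c1` carries 4-chloro-3-(trifluoromethyl)phenyl in place of 3,5-dichlorophenyl on a carbonyl carbon. Compound 1 holds the same 4-chloro-3-(trifluoromethyl)phenyl amide, and its number falls within the scatter of that of compound 3. Within the data shown here, with the only bearing step flat, no movement beyond the scatter is expected, a 1.0-fold higher number from compound 3 to compound 4 (0.01 log units; within the scatter). Compound 4 is therefore expected at 2800 nM, between 1400 nM and 5600 nM.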

Compound 4, half-maximal inhibitory concentration: 1080 nM
The estimate for compound 4 lay 2.6-fold (0.41 log units) above the measured number, outside the stated range (below it).
By their numbers in this assay, from the lowest: compound 4; then compounds 3, 1 and 2 (each within the scatter of the next).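

In this assay, the aryl group on the amide carbonyl now moves the number: trifluoromethyl in place of chloro on an aromatic carbon gives a step beyond the scatter (a 2.7-fold lower number from compound 2 to compound 4 (0.43 log units; beyond the scatter)), as does 4-chloro-3-(trifluoromethyl)phenyl in place of 3,5-dichlorophenyl (a 2.5-fold lower number from compound 3 to compound 4 (0.41 log units; beyond the scatter)), whereas the earlier dichlorophenyl change stayed flat (a 1.1-fold lower number from compound 2 to compound 3 (0.03 log units; within the scatter)). With this amide, the group on the oxygen on the aromatic ring also counts, with hydrogen in place of methyl (a 2.6-fold lower number from compound 1 to compound 4 (0.41 log units; beyond the scatter)). Nothing available explains either step. From the compounds shown here alone, whether the effect is specific to trifluoromethyl stays open, and a nitrile at that carbon would test this. An ethyl group on the oxygen would extend the hydrogen and methyl comparison.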